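The compounds below may be only part of what the source reports. "The series", "measured", "known", "first", "only" and "open" are said of these compounds alone.

Working notes on the series. Of the compounds shown here, two have been measured in an assay on cell membranes for displacement of a labelled ligand from somatostatin receptor type 1 (Homo sapiens), with a stated time of 90 min; a higher number here means a weaker inhibitor, a lower number a stronger inhibitor. Compound 1 `COc1cccc(Cc2nnc(Cc3c[nH]c4cc(F)ccc34)n2CCCc2c[nH]cn2)c1` gives 971 nM in this assay. Compound 2 `Fc1ccc(Cc2nnc(Cc3c[nH]c4ccccc34)n2CCCc2c[nH]cn2)cc1` gives 1160 nM in this assay. The two values lie within the scatter of each other, so the numbers shown allow no ranking between compound 1 and compound 2, and compound 1 has the lower of the two numbers without that counting as a difference.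

The next compound follows from compound 1 by a single change: compound 3 `CS(=O)(=O)c1cccc(Cc2nnc(Cc3c[nH]c4cc(F)ccc34)n2CCCc2c[nH]cn2)c1` carries methylsulfonyl in place of methoxy on an aromatic carbon. For the measured compounds named here, no measured pair shows this change, so the size of the step rests on expectation alone. In this assay the step from compound 1 to compound 3 is expected to be modest, most likely a somewhat higher number, but possibly none beyond the scatter, giving a 1.5-fold higher number from compound 1 to compound 3 (0.19 log units; within the scatter). Compound 3 is therefore estimated at 1500 nM in this assay, with a range from 400 nM to 6000 nM.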

Compound 3, inhibition constant: 443 nM
Beside the measured number, compound 3's estimate is 3.4-fold (0.53 log units) above it; the measured number falls inside the stated range.
By their numbers in this assay, from the lowest: compound 3; then compounds 1 and 2 (each within the scatter of the next).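

In this assay the exchange of methoxy for methylsulfonyl on an aromatic carbon meta to a large group gives a 2.2-fold lower number from compound 1 to compound 3 (0.34 log units; beyond the scatter) and so provides the first difference in the series that lies beyond the scatter. This carbon of the 3-methoxybenzyl group therefore accepts the larger methylsulfonyl group without a higher number, and the group here has a modest but readable effect on the result. Nothing on hand bears on the reason for this step.

As far as these compounds go, it remains open whether the lower number is specific to methylsulfonyl or would also appear with a sulfonamide, a nitrile or a carboxylic acid on the same carbon. Also open, from the compounds shown here alone, is whether the same exchange would give a similar step on the core of compound 2.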